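The compounds below may be only part of what the source reports. "The series", "measured", "known", "first", "only" and "open" are said of these compounds alone.

Compound 1 `Cc1cc(O)c(C(C)C)cc1-c1cc(-c2ccccc2)c(C#N)c(=O)[nH]1`: in a functional assay for inhibition, tested at 40 ug/mL (on this read-out higher numbers stand for a stronger effect at the one concentration tested and lower numbers for a weaker effect), compound 1 gives 29%.
Compound 2 `COc1ccc(-c2cc(-c3cc(C(C)C)c(O)cc3C)[nH]c(=O)c2C#N)c(OC)c1`: in this assay compound 2 gives 37.5%.
Compound 3 `COc1ccc(-c2cc(-c3cc(C(C)C)c(O)cc3C)[nH]c(=O)c2C#N)cc1`: in this assay compound 3 gives 35%.

Compound 2 gives the top number of the three, yet it does not stand apart: the step of a number 8.5 percentage points higher from compound 1 to compound 2 (within the scatter) and the step of a number 2.5 percentage points lower from compound 2 to compound 3 (within the scatter) are both within the scatter, so on these numbers the three compounds cannot be told from one another.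

Compound 4 `COc1cc(OC)c(-c2cc(-c3cc(C(C)C)c(O)cc3C)[nH]c(=O)c2C#N)c(OC)c1` has not yet been measured. It differs from compound 2 in one place: methoxy in place of hydrogen on an aromatic carbon. Two measured steps speak to a change of this kind. Putting a methoxy on an aromatic carbon gave a number 6 percentage points higher from compound 1 to compound 3 (within the scatter), and removing one gave a number 2.5 percentage points lower from compound 2 to compound 3 (within the scatter); neither moved the read-out beyond the scatter. A third methoxy on that six-membered aromatic ring of carbon only is therefore expected to change little, and the expected step of a number 0.5 percentage points higher from compound 2 to compound 4 (within the scatter) lies within the scatter. Compound 4 is estimated to give 38% in this assay, with a range from 25% to 51%.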

Compound 4, a percentage reported as inhibition, at one concentration (the size of the read-out at that concentration, not a potency): 52.6%
For compound 4 the middle estimate is 14.6 percentage points below the measured one; the measured number lies above the stated range.
By their numbers in this assay, from the lowest: compounds 1, 3 and 2 (each within the scatter of the next); then compound 4.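

In this assay, a third methoxy on the six-membered aromatic ring of carbon only, ortho to a large group and meta to two methoxy groups, gave a number 15.1 percentage points higher from compound 2 to compound 4 (beyond the scatter). This is the first step among these compounds to clear the usual scatter, so this position accepts a methoxy and the read-out can respond to a change made there, which the earlier steps could not show. Even so, the result does not establish that this methoxy acts differently here from the one added on the other core, as the two steps cannot be told apart: the same change on two cores in this assay, a number 6 percentage points higher (within the scatter) from compound 1 to compound 3 and a number 15.1 percentage points higher (beyond the scatter) from compound 2 to compound 4, 9.1 percentage points apart, within the scatter of two such steps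

The compounds shown leave open whether the rise belongs to methoxy in particular or would also appear with another group at this position, such as a hydroxyl, a fluorine, an ethoxy or an amine. They also show the rise only as a stronger effect at a single concentration, and each number gives the size of the effect at that concentration and no more.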